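Chain substituent variation on the shared core

The compounds below may be only part of what the source reports. "The series", "measured", "known", "first", "only" and "open" are said of these compounds alone.

Compound 1, `CCc1nnc2c(C#N)c(N3CCC(c4ccccc4)CC3)ccn12`: 696 nM
Compound 2, `N#Cc1c(N2CCC(c3ccccc3)CC2)ccn2c(CC(F)(F)F)nnc12`: 56 nM

Among the measured compounds shown here, in a functional assay on CHO cells for positive allosteric modulation of metabotropic glutamate receptor 2 (Homo sapiens), read by GTPgammaS binding, with a stated time of 30 min (a higher number here means that more compound is needed for the effect, a lower number that less compound is needed), compound 2 gives the lowest of the two numbers measured; the single step of a 12-fold lower number from compound 1 to compound 2 (1.09 log units; beyond the scatter) separates it from compound 1. Compound 3, `N#Cc1c(N2CCC(c3ccccc3)CC2)ccn2c(CN3CCCC3)nnc12`, carries the change (pyrrolidin-1-yl in place of trifluoromethyl on a saturated chain carbon bound to an aromatic carbon). For the measured compounds named here, only that one step touches this position, and it concerns a different pair of groups, so it sets no direction for the new group; its large size does show that this position can move the read-out strongly. Going by the values given here, with no closer precedent, compound 3 is expected to land between the two measured numbers, at 250 nM with a range of 60 nM to 1000 nM. This estimate amounts to an expected step of a 4.5-fold higher number from compound 2 to compound 3 (0.65 log units; beyond the scatter).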

Compound 3, half-maximal effective concentration: 1120 nM
The estimate for compound 3 lay 4.5-fold (0.65 log units) below the measured number; the whole stated range lies below it.
By their numbers in this assay, from the lowest: compound 2; then compounds 1 and 3 (each within the scatter of the next).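

In this assay the low number does not extend to every group on this saturated chain carbon: pyrrolidin-1-yl in place of trifluoromethyl gives a 20-fold higher number from compound 2 to compound 3 (1.30 log units; beyond the scatter) and removes the whole gain seen with trifluoromethyl. Pyrrolidin-1-yl and methyl at this place are not separated, with a 1.6-fold higher number from compound 1 to compound 3 (0.21 log units; within the scatter) as their step, so only trifluoromethyl stands apart among the three groups. No measured evidence here accounts for this difference.

Open, from the compounds shown here alone, is whether a longer fluorinated chain keeps the low number of compound 2. Also open, going by these compounds, is whether an open-chain amine such as dimethylamino or a morpholine ring behaves like pyrrolidin-1-yl.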